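The compounds below may be only part of what the source reports. "The series", "measured", "known", "first", "only" and "open" are said of these compounds alone.

Compound 1 `Cc1ccc([C@@H](C)NC(=O)c2cc([N+](=O)[O-])c(C)c([N+](=O)[O-])c2)cc1` gives > 58200 nM in an ADME assay on J774 cells (Mus musculus) for cytotoxicity, read by MTT assay, with a stated time of 24 h; a higher number here means a weaker inhibitor, a lower number a stronger inhibitor.
Compound 2 `Cc1c([N+](=O)[O-])cc(C(=O)N[C@H](C)c2ccc(F)cc2)cc1[N+](=O)[O-]` gives > 57600 nM in this assay.

Both numbers are limits of this assay rather than measured values. Compound 1 sits at the limit of > 58200 nM in this assay, at which 1 of the 2 values shown sits. Compound 2 sits at the limit of > 57600 nM in this assay, at which 1 of the 2 values shown sits. Among the compounds with values here, compound 2 therefore stands at a limit, and the one other value shown is a limit as well. Within the data shown here, the single measured step, a step that the two limits leave unreadable from compound 1 to compound 2, cannot be read in size or direction. Compound 3 `Cc1c([N+](=O)[O-])cc(C(=O)N[C@@H](C)c2ccc(F)cc2)cc1[N+](=O)[O-]` differs from compound 2 in this way: the two compounds have the same atoms and bonds and differ only in configuration as drawn: 1 of 1 stereo elements differ; a stereocentre at a saturated chain carbon is drawn R in compound 2 and S in compound 3. No measured step involves a change of configuration alone, and the only step shown is unreadable, so no direction beyond the scatter can be taken from the data. Compound 3 is expected to give 58000 nM in this assay, with a range of 20000 nM to 150000 nM, most likely reported again as a limit. The step that the limit leaves unreadable from compound 2 to compound 3 is expected to stay within the scatter.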

Compound 3, half-maximal inhibitory concentration: > 57600 nM
Compound 3 ended at the assay's limit; the forecaster's own chance of this, stated with the estimate: 80%; the middle value is on the limit's open side.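

Compound 2 and compound 3 both stand at a limit of this assay rather than at a measured value, and the step between them cannot be read. The compounds shown leave open where their true values lie, and whether the configuration at the saturated chain carbon matters at all.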